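Trifluoromethoxy in place of bromo: the next solubility step

This account rests on a few compounds, and the source may have more. Where it says the series, first, only, none or still open, it means among the compounds named here.

In a physicochemical assay for solubility, read by spectrophotometry, in phosphate buffer, with a stated time of 18 h, at pH 7.4 (on this read-out lower numbers stand for lower solubility and higher numbers for higher solubility), compound 1 (`CCc1ccc(-c2nc3c(c(C)nn3-c3ccccc3)c(-c3ccccc3Br)c2C#N)cc1`) gives 1500 nM and compound 2 (`CCc1ccc(-c2nc3c(c(C)nn3-c3ccccc3)c(-c3ccccc3Cl)c2C#N)cc1`) gives 1700 nM with the two level within the scatter. Compound 3 (`CCc1ccc(-c2nc3c(c(C)nn3-c3ccccc3)c(-c3ccccc3C(=O)O)c2C#N)cc1`) stands far from both at 33000 nM and is the only one of the three with a carboxy group. Compound 4 (`CCc1ccc(-c2nc3c(c(C)nn3-c3ccccc3)c(-c3ccccc3OC(F)(F)F)c2C#N)cc1`) carries trifluoromethoxy in place of bromo on an aromatic carbon, ortho to a large group (trifluoromethoxy in place of bromo on an aromatic carbon). The large steps to compound 3 (a 22-fold higher number from compound 1 to compound 3 (1.34 log units; beyond the scatter) and a 19-fold higher number from compound 2 to compound 3 (1.29 log units; beyond the scatter)) both bring in carboxy, which compound 4 does not have, so they bear little on this change. Going by the values given here, the closer guide is the swap of chloro for bromo (a 1.1-fold higher number from compound 1 to compound 2 (0.05 log units; within the scatter)), although no measured step involves trifluoromethoxy. A small estimated step (a 1.3-fold lower number from compound 1 to compound 4 (0.10 log units; within the scatter)) is therefore expected in this assay with no change in either direction beyond the scatter. Compound 4 is estimated at 1200 nM (expected range 500 nM to 2800 nM).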

Compound 4, solubility: 9900 nM
For compound 4 the middle estimate is 8.3-fold (0.92 log units) below the measured one, and the stated range ends below it.
By their numbers in this assay, from the lowest: compounds 1 and 2 (each within the scatter of the next); then compound 4; then compound 3.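

At this place, on an aromatic carbon ortho to a large group, bromo and chloro sit level in this assay, but trifluoromethoxy separates from both: a 6.6-fold higher number from compound 1 to compound 4 (0.82 log units; beyond the scatter) and a 5.8-fold higher number from compound 2 to compound 4 (0.77 log units; beyond the scatter). A step beyond the scatter here therefore does not depend on carboxy alone, although the series still shows a 3.3-fold lower number from compound 3 to compound 4 (0.52 log units; beyond the scatter), which leaves compound 4 between the halogen compounds and the carboxy compound. No measurement at hand accounts for the rise with trifluoromethoxy.

Whether methoxy or trifluoromethyl at this place would give a similar step remains open, so the compounds shown do not tell which part of trifluoromethoxy matters. Also open, from the compounds shown here alone, is whether the same swap gives a step of similar size on a different core.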